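The compounds below may be only part of what the source reports. "The series", "measured", "known", "first", "only" and "open" are said of these compounds alone.

Compound 2 `Cc1nc(-c2ccc(C(F)(F)F)cc2)sc1CNc1ccc(CC(C)C(=O)O)cc1` gives 100% in a functional assay on CHO cells for agonist activity at Free fatty acid receptor 1 (Homo sapiens), read by a luciferase reporter (on this read-out lower numbers stand for smaller maximal responses and higher numbers for larger maximal responses), the higher of the two numbers shown, while compound 1 `Cc1nc(-c2ccc(C(F)(F)F)cc2)sc1CNc1ccc(C(=O)O)cc1` gives 10% in this assay. For the measured compounds named here, the only measured step, a number 90 percentage points higher from compound 1 to compound 2 (beyond the scatter), is large. Compound 3 `Cc1nc(-c2ccc(C(F)(F)F)cc2)sc1CNc1ccc([C@H]2C[C@@H]2C(N)=O)cc1` differs from compound 2 by 2-carbamoylcyclopropyl in place of 2-carboxypropyl on an aromatic carbon. Going by the values given here, that measured step bears on this change only loosely, since it concerns the arrival of 2-carboxypropyl rather than its replacement; no step among the measured compounds touches a 2-carbamoylcyclopropyl group. Compound 3 is therefore expected to give 25% in this assay, within 5% to 70%, an expected step of a number 75 percentage points lower from compound 2 to compound 3 (beyond the scatter).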

Compound 3, largest response reached (reported as percent of maximum), in percent of the reference or control that the assay uses: 80%
Estimate against measurement, compound 3: 55 percentage points below, and the stated range ends below it.
By their numbers in this assay, from the lowest: compound 1; then compound 3; then compound 2.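

At this place on the aromatic ring, para to a large group, 2-carboxypropyl can give way to 2-carbamoylcyclopropyl at only a modest cost in this assay, with a number 20 percentage points lower from compound 2 to compound 3 (beyond the scatter). The new group also holds nearly all of the gain over carboxy, with a number 70 percentage points higher from compound 1 to compound 3 (beyond the scatter), so a large response here is not confined to 2-carboxypropyl. Nothing measured here explains this result.

The compounds shown leave open whether the response follows the three-membered ring or the carbamoyl group, which a carboxylic acid on that ring or an open-chain amide could separate. From the compounds shown here alone, the role of the two defined stereocentres of compound 3 also stays open.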